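Removing the chloro: an expectation for compound 4 in cytotoxicity

A few compounds are considered here, and "the series" means these few. Any claim that something is new, unique, unknown or untested is made for them only; others in the source may bear on it.

Compound 1 `Cc1cc(O)c(C(=O)/C=C/c2cccc(Cl)c2)c(-c2ccccc2)c1C(=O)/C=C/c1cccc(Cl)c1`: 15000 nM
Compound 2 `Cc1cc(O)c(C(=O)/C=C/c2ccc3ccccc3c2)c(-c2ccc(Cl)cc2)c1C(=O)/C=C/c1ccc2ccccc2c1`: "not active" (no number reported)
Compound 3 `Cc1cc(O)c(C(=O)/C=C/c2ccc(OCc3ccccc3)cc2)c(-c2ccc(OCc3ccccc3)cc2)c1C(=O)/C=C/c1ccc(OCc2ccccc2)cc1`: 30000 nM

Of the compounds shown here, three sharing one core have been measured in an ADME assay on HEK293 cells (Homo sapiens) for cytotoxicity, read by MTT assay, with a stated time of 24 h; a higher number here means a weaker inhibitor, a lower number a stronger inhibitor. Compound 1 gives 15000 nM and compound 3 gives 30000 nM, both weak. Compound 2 stands apart: in this assay compound 2 is reported as "not active" (no number reported), with no number attached, so it cannot be placed against compounds 1 and 3 on a scale, only grouped with them as weak.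

Compound 4 `Cc1cc(O)c(C(=O)/C=C/c2ccc3ccccc3c2)c(-c2ccccc2)c1C(=O)/C=C/c1ccc2ccccc2c1` is the unmeasured partner of compound 2. The change is hydrogen in place of chloro on an aromatic carbon. The 4-chlorophenyl becomes phenyl; the naphthyl arms are unchanged. Among the measured compounds shown here, no measured pair shows what this change does here, so the expected step in this assay is none beyond the scatter, in either direction, and compound 4 is expected to remain weak like compounds 1, 2 and 3. Compound 4 is estimated at 25000 nM, with a range from 10000 nM to 70000 nM, and a real chance that only a limit is reported.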

Compound 4, half-maximal inhibitory concentration: "not active" (no number reported)
The entry for compound 4 holds no number, so the estimate cannot be set against anything.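

Neither compound 2 nor compound 4 carries a number in this assay, so no step can be read between them. Nothing given here bears on this result. The compounds shown leave open whether going from 4-chlorophenyl to phenyl shifts cytotoxicity at all.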